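A Thiophenyl Swap Toward Compound 3

The source may report more compounds than this note shows. Statements on the series, on what has been measured and on what is new or still open speak of the compounds shown alone.

Compound 1, `Cc1ccsc1C(=O)/C=C/c1ccc(N2CCCCC2)cc1`: 26400 nM
Compound 2, `c1cc(C2=NNC(c3ccc(N4CCCCC4)cc3)C2)cs1`: > 100000 nM

Both measured compounds were run in an ADME assay on PBMC cells (Homo sapiens) for cytotoxicity, with a stated time of 5 days; a lower number here means a stronger inhibitor, a higher number a weaker inhibitor. Compound 1 gives 26400 nM. For compound 2 the assay reports only a limit, > 100000 nM, so where compound 2 truly stands is not known; it sits at the limit of > 100000 nM in this assay, at which 1 of the 2 values shown sits. Compound 3, `Cc1csc(C2=NNC(c3ccc(N4CCCCC4)cc3)C2)c1`, has not been measured yet. It differs from compound 2 in a single place: 4-methylthiophen-2-yl in place of thiophen-3-yl on a carbon with a double bond to nitrogen. Among the compounds with values here, no pair of measured compounds shows what this kind of change does in this assay, so there is no measured step to build on. With compound 2 already at the limit, the expectation is for no shift beyond the usual scatter. The estimated result for compound 3 is 100000 nM, within a range of 40000 nM to 250000 nM. The expected step that this estimate means is a number no higher from compound 2 to compound 3 (the limit leaves the size open).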

Compound 3, half-maximal inhibitory concentration: 24400 nM
Beside the measured number, compound 3's estimate is 4.1-fold (0.61 log units) above it, outside the stated range (below it).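

In this assay, the group on this carbon with a double bond to nitrogen turns out to matter: putting 4-methylthiophen-2-yl in place of thiophen-3-yl gives an at least 4.0-fold lower number from compound 2 to compound 3 (0.61 log units; beyond the scatter). Within the data shown here, until now, no measured pair showed what a change at this place does. The new pair shows that a small swap between two thiophene groups here can move the number by more than the usual scatter.

The swap adds a methyl group and also moves the point of attachment on the thiophene, and the compounds shown do not separate these two changes or show what a different group here, such as an amine or a carboxylic acid, would do. The true size of the step also stays open, because compound 2 stands at a limit and not at a number: the limit of > 100000 nM in this assay, at which 1 of the 3 values shown sits.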